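The source may report more compounds than this note shows. Statements on the series, on what has been measured and on what is new or still open speak of the compounds shown alone.

Three compounds share one core and differ only in the group carried on an amine nitrogen in a ring. Compound 1 `Cc1cccc2sc(NC(=O)CCN3CCN(C(C)(C)C)CC3)nc12` carries a tert-butyl group there, and in an assay on membranes from liver for displacement of a labelled ligand from Sigma intracellular receptor 2 (Rattus norvegicus), read by scintillation counting, with a stated time of 120 min (a lower number here means a stronger inhibitor, a higher number a weaker inhibitor), compound 1 gives 200 nM. Compound 2 `Cc1cccc2sc(NC(=O)CCN3CCN(CCN(C)C)CC3)nc12` carries 2-(dimethylamino)ethyl instead; for compound 2 this assay reports only a limit, > 1000 nM. Compound 3 `Cc1cccc2sc(NC(=O)CCN3CCN(CC4CCCCC4)CC3)nc12` carries cyclohexylmethyl, and in this assay compound 3 gives 519 nM. Going by the values given here, of the two numbers known, compound 3 holds the higher one, since the step of a 2.6-fold higher number from compound 1 to compound 3 (0.41 log units; beyond the scatter) lies beyond the scatter, while the step of an at least 1.9-fold lower number from compound 2 to compound 3 (0.28 log units; that floor lies within the scatter) sets only a floor that lies within it.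

Compound 4 `Cc1ccccc1N1CCN(CCC(=O)Nc2nc3c(C)cccc3s2)CC1` has not yet been measured. It differs from compound 3 in one place: 2-methylphenyl in place of cyclohexylmethyl on an amine nitrogen in a ring. Among the compounds with values here, two measured steps bear on this change, both leaving tert-butyl for a larger group: an at least 5.0-fold higher number from compound 1 to compound 2 (0.69 log units; beyond the scatter) and a 2.6-fold higher number from compound 1 to compound 3 (0.41 log units; beyond the scatter). From the compounds shown here alone, both moved toward weaker binding, but neither involves an aromatic ring placed directly on that nitrogen, so the direction for compound 4 remains open. The expectation for compound 4 is therefore a step near or within the scatter, a 1.3-fold lower number from compound 3 to compound 4 (0.11 log units; within the scatter). For compound 4 in this assay the estimated value is 400 nM, expected to lie between 120 nM and 1500 nM.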

Compound 4, inhibition constant: > 1000 nM
Compound 4: no number, only a limit; the forecaster's own chance of this, stated with the estimate: 20%; at least 2.5-fold (0.39 log units) between middle value and limit.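

Placing an aromatic ring directly on the amine nitrogen in a ring, with 2-methylphenyl in place of the saturated ring of cyclohexylmethyl and the same count of heavy atoms, gives an at least 1.9-fold higher number from compound 3 to compound 4 (0.28 log units; that floor lies within the scatter), so this result alone does not separate compound 4 from compound 3. Measured against tert-butyl, the same change gives an at least 5.0-fold higher number from compound 1 to compound 4 (0.69 log units; beyond the scatter), which makes 2-methylphenyl the third group at this position to give a clearly higher number than tert-butyl, after 2-(dimethylamino)ethyl and cyclohexylmethyl. From the compounds shown here alone, the step between compound 2 and compound 4 cannot be read, and the true size of the loss for compound 4 stays unknown, because both compounds give only a limit: the limit of > 1000 nM in this assay, at which 2 of the 4 values shown sit.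

The compounds shown leave open whether the methyl on the aromatic ring matters, which a plain phenyl group on the same nitrogen would help to test. Going by these compounds, it also remains open whether an alkyl group smaller than tert-butyl, such as methyl or isopropyl, would give a lower number than compound 1 in this assay.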